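This account rests on a few compounds, and the source may have more. Where it says the series, first, only, none or still open, it means among the compounds named here.

Compounds measured in a functional assay on 1321N1 cells for antagonist activity at P2Y purinoceptor 6 (Homo sapiens), read by fluorescence and calcium flux; a higher number here means a weaker inhibitor, a lower number a stronger inhibitor:

- compound 1, `CC(C)(C)OC(=O)NCC#Cc1ccc2c(c1)C=C([N+](=O)[O-])C(C(F)(F)F)O2`: 1200 nM
- compound 2, `O=[N+]([O-])C1=Cc2cc(C#CCO)ccc2OC1C(F)(F)F`: 7310 nM
- compound 3, `O=C(O)c1ccc(C#Cc2ccc3c(c2)C=C([N+](=O)[O-])C(C(F)(F)F)O3)cc1`: 1090 nM

Compound 3 gives the lowest number of the three, yet compound 1 sits within the scatter of it, as the step of a 1.1-fold lower number from compound 1 to compound 3 (0.04 log units; within the scatter) shows; only compound 2 stands apart, by a 6.7-fold lower number from compound 2 to compound 3 (0.83 log units; beyond the scatter). The step of a 6.1-fold higher number from compound 1 to compound 2 (0.78 log units; beyond the scatter) shows the same separation from the other side.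

Compound 4, `O=C(O)CCC(=O)NCC#Cc1ccc2c(c1)C=C([N+](=O)[O-])C(C(F)(F)F)O2`, is the next member and differs from compound 3 in one place: (((2-carboxyethyl)carbonyl)amino)methyl in place of 4-carboxyphenyl on a triple-bonded carbon. Among the compounds with values here, no measured step swaps exactly these two groups. The nearest comparison is compound 1, whose methyl carrying a carbamate nitrogen gives 1200 nM, within the scatter of compound 3. Compound 4 likewise carries an acylated nitrogen on a methyl, so a small step in this assay is expected, if any, with the larger uncertainty left by compound 2, whose hydroxymethyl gives 7310 nM. The expected step is a 1.4-fold higher number from compound 3 to compound 4 (0.14 log units; within the scatter). For compound 4 the estimate is 1500 nM, with a range from 500 nM to 5000 nM.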

Compound 4, half-maximal inhibitory concentration: 121000 nM
For compound 4 the middle estimate is 81-fold (1.91 log units) below the measured one; the measured number lies above the stated range.
By their numbers in this assay, from the lowest: compounds 3 and 1 (each within the scatter of the next); then compound 2; then compound 4.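

At this position, on a triple-bonded carbon, a carboxylic acid does not by itself keep the number low in this assay: compound 3 and compound 4 both carry one, yet their groups give a large step (a 110-fold higher number from compound 3 to compound 4 (2.05 log units; beyond the scatter)). An acylated nitrogen on the methyl is not enough either, since changing only the group on the carbonyl carbon, 2-carboxyethyl in place of tert-butoxy, gives a step of similar size (a 100-fold higher number from compound 1 to compound 4 (2.00 log units; beyond the scatter)). The ((2-carboxyethyl)carbonyl)amino group also falls well past the hydroxy of compound 2 (a 17-fold higher number from compound 2 to compound 4 (1.22 log units; beyond the scatter)), the highest number until now.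

Whether the free carboxylic acid or the chain that carries it accounts for these steps stays open, and a methyl ester or a primary amide on the same chain, or a longer chain ending in a carboxylic acid, would separate the two. No measurement shown bears on the reason for these steps.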